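This account rests on a few compounds, and the source may have more. Where it says the series, first, only, none or still open, it means among the compounds named here.

Measured so far in an in vitro functional assay on cells for agonist activity at Bombesin receptor subtype-3 (Homo sapiens), read by luminescence and calcium flux; a higher number here means that more compound is needed for the effect, a lower number that less compound is needed:
- compound 1, `O=C(O)c1ccccc1-c1ccc(CCc2ncc(CCc3ccccc3)[nH]2)cc1`: 1320 nM
- compound 2, `CCCCc1cnc(/C=C/c2ccc(-c3ccccc3C(=O)O)cc2)[nH]1`: 4380 nM

Compound 1 holds the lower of the two numbers in this assay; compound 2 sits a good deal higher, and the gap between the two lies beyond the usual scatter. Within the data shown here, the two differ in more than one place at once, so their values do not isolate any single change, and no pair of measured compounds differs in just one place.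

Compound 3, `COc1ccccc1Cc1cnc(CCc2ccc(-c3ccccc3C(=O)O)cc2)[nH]1`, has not yet been measured. It differs from compound 1 in one place: 2-methoxyphenyl in place of benzyl on a saturated chain carbon bound to an aromatic carbon. In the words of the counted difference, the phenethyl arm of compound 1 becomes a 2-methoxybenzyl arm in compound 3, the chain being one link shorter while one hydrogen-bond acceptor comes in.

With nothing measured on this side of the series, the expected step is uncertain and is set near no change, leaning slightly toward a higher number: the step expected from compound 1 to compound 3 in this assay is a 1.2-fold higher number from compound 1 to compound 3 (0.08 log units; within the scatter). Compound 3 is accordingly estimated at 1600 nM in this assay, within a range of 400 nM to 6500 nM.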

Compound 3, half-maximal effective concentration: 1720 nM
Compound 3: middle estimate off by 1.1-fold (0.03 log units), on the low side; measured number inside the range.
By their numbers in this assay, from the lowest: compounds 1 and 3 (each within the scatter of the next); then compound 2.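

In this assay, among these compounds, 2-methoxyphenyl in place of benzyl on a saturated chain carbon bound to an aromatic carbon gives a 1.3-fold higher number from compound 1 to compound 3 (0.11 log units; within the scatter), the first step that changes one place only. This position therefore tolerates the exchange of a phenethyl arm for a 2-methoxybenzyl arm without a change that can be told from the scatter, even though the chain is one link shorter and a hydrogen-bond acceptor comes in. No supporting data bear on this result, so the flat step stands as an observation without an explanation.

The two parts of the change arrive together, so the shorter chain and the methoxy group cannot be separated here, and a 2-hydroxybenzyl arm, a 2-fluorobenzyl arm or a longer chain such as phenylpropyl would be needed to show how far this position really tolerates change. Also open, going by these compounds, is whether an amine on this arm, or a tetrazole in place of the carboxylic acid shared by all three compounds, would move the number beyond the scatter.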